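A few compounds are considered here, and "the series" means these few. Any claim that something is new, unique, unknown or untested is made for them only; others in the source may bear on it.

Compound 1, `N=C(NCc1ccccc1)[C@@H]1CCC(=O)N1Cc1ccccc1`, gives 27.9% in a functional assay on SH-SY5Y cells (Homo sapiens) for cytotoxicity, read by MTT assay, with stated times of 8 h, 30 min and 12 h, tested at 0.5 uM (on this read-out higher numbers stand for a stronger effect at the one concentration tested and lower numbers for a weaker effect), which places it second highest among the three measured compounds, with both neighbours within the scatter. Compound 2, `COc1ccc(CNC(=N)[C@@H]2CCC(=O)N2Cc2ccccc2)cc1`, gives 23.6% in this assay, and compound 3, `N=C(NCc1ccccc1)[C@@H]1CCC(=O)N1Cc1ccccc1[N+](=O)[O-]`, gives 28.8%. The step of a number 4.3 percentage points lower from compound 1 to compound 2 (within the scatter) and the step of a number 0.9 percentage points higher from compound 1 to compound 3 (within the scatter) were both within the scatter. Compound 4, `N=C(NCc1ccccc1)[C@@H]1CCC(=O)N1Cc1ccc(F)cc1`, differs from compound 1 by fluoro in place of hydrogen on an aromatic carbon, a fluoro on the ring that also carries the nitro in compound 3. Since neither substitution on an aromatic carbon moved the read-out beyond the scatter, a step of a number 0.9 percentage points lower from compound 1 to compound 4 (within the scatter) is expected, none beyond the scatter. Compound 4 is therefore estimated at 27%, with a range from 18% to 36%.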

Compound 4, a percentage reported as activity, at one concentration (the size of the read-out at that concentration, not a potency): 23.3%
Compound 4: middle estimate off by 3.7 percentage points, on the high side; the measured number falls inside the stated range.
By their numbers in this assay, from the lowest: compounds 4, 2, 1 and 3 (each within the scatter of the next).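

In this assay, the change from benzyl to 4-fluorobenzyl gives a number 4.6 percentage points lower from compound 1 to compound 4 (within the scatter), so a fluoro at this place, para to a large group, does not move the read-out beyond the scatter. Together with compounds 2 and 3, this makes three single substitutions on an aromatic carbon, none with a step from compound 1 beyond the scatter. Nothing available here bears on the reason for this result. On these data alone, whether an amine or a carboxylic acid at this place would also stay within the scatter remains open.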